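Cytotoxicity notes: amine substituent change, compound 2 to compound 3

The source may report more compounds than this note shows. Statements on the series, on what has been measured and on what is new or still open speak of the compounds shown alone.

Compound 1 `Cc1cn([C@@H]2O[C@H](CO[Si](C)(C)C(C)(C)C)[C@@]3(OS(=O)(=O)C=C3NC(=O)c3ccccc3)[C@H]2O[Si](C)(C)C(C)(C)C)c(=O)n(C)c1=O` and compound 2 `COC(=O)CCNC1=CS(=O)(=O)O[C@@]12[C@@H](CO[Si](C)(C)C(C)(C)C)O[C@@H](n1cc(C)c(=O)n(C)c1=O)[C@@H]2O[Si](C)(C)C(C)(C)C` share one core and differ only in the group on the amine nitrogen. In a functional assay on HEL cells (Homo sapiens) for cytotoxicity, read by microscopy (a lower number here means that less compound is tolerated, a higher number that more compound is tolerated), compound 1 gives only a limit, >= 3200 nM. In this assay compound 2 likewise gives only a limit, >= 400000 nM. The step that the two limits leave unreadable from compound 1 to compound 2 therefore cannot be read, since both ends are limits, namely the limit of >= 3200 nM in this assay, at which 1 of the 2 values shown sits, and (the limit of >= 400000 nM in this assay, at which 1 of the 2 values shown sits). Compound 2 thus stands at the higher of the two limits, with no numerical value anywhere beside it.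

Compound 3 `Cc1cn([C@@H]2O[C@H](CO[Si](C)(C)C(C)(C)C)[C@@]3(OS(=O)(=O)C=C3NCC(N)=O)[C@H]2O[Si](C)(C)C(C)(C)C)c(=O)n(C)c1=O` differs from compound 2 by carbamoyl in place of (methoxycarbonyl)methyl on a saturated chain carbon bound to an amine nitrogen. Among the measured compounds shown here, no readable measured step in this assay bears on this change; the single measured step, a step that the two limits leave unreadable from compound 1 to compound 2, concerns a different exchange on the same nitrogen and has no readable size. No step beyond the scatter is expected here. The estimated step is a number no higher from compound 2 to compound 3 (the limit leaves the size open). Compound 3 is expected to reach the same limit as before, estimated at 400000 nM, within 100000 nM to 1000000 nM.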

Compound 3, minimum cytotoxic concentration: 16000 nM
Estimate against measurement, compound 3: 25-fold (1.40 log units) above; the whole stated range lies above it.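

In this assay, among the compounds shown here, carbamoyl in place of (methoxycarbonyl)methyl on a saturated chain carbon bound to an amine nitrogen gives an at least 25-fold lower number from compound 2 to compound 3 (1.39 log units; beyond the scatter), so compound 3 is less well tolerated and supplies the first reading that is a number and not a limit. This shows that the group on the amine nitrogen is not indifferent for cytotoxicity, something the earlier pair could not show, as the steps from compound 1 to compound 2 and from compound 1 to compound 3 cannot be read. The values shown are cytotoxicity readings alone and tie this step to no property of either group.

Read one bond further out, the change runs from 2-(methoxycarbonyl)ethyl to carbamoylmethyl, so the chain and its end group change together and the share of each in the step stays open. A 2-carbamoylethyl group on the same nitrogen would separate the two, and a carboxylic acid at the chain end would test whether the methyl ester itself matters.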